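Series notes: aryl ester variation on a shared core

The source may hold more compounds than are shown below. What is called first, only, known or untested is meant among the compounds shown, and "the series" means these compounds.

Measured so far:
- compound 1 `COc1ccc(C(=O)Oc2cc3c(C)ccc(C(C)C)c3cc2C)cc1`: in a functional assay on MCF7 cells (Homo sapiens) for antiproliferative activity, read by sulforhodamine B assay, with a stated time of 48 h, tested at 50 uM (on this read-out lower numbers stand for less inhibition and higher numbers for more inhibition at the one concentration tested (going by the name of the read-out)), compound 1 gives 93.4%
- compound 2 `Cc1cc2c(C(C)C)ccc(C)c2cc1OC(=O)c1ccc(C(F)(F)F)cc1`: in this assay compound 2 gives 16.8%
- compound 3 `CC1=CC[C@H](C(C)C)c2cc(C)c(OC(=O)c3ccc([N+](=O)[O-])cc3)cc21`: in this assay compound 3 gives 72.9%

On these three numbers compound 3 stands second highest: compound 1 sits higher by a margin beyond the scatter, and compound 2 sits far lower, also beyond the scatter. Within the data shown here, the only single-place step measured in the set is a number 76.6 percentage points lower from compound 1 to compound 2 (beyond the scatter), a large downward move obtained by changing the same ring position of the benzoate, though on a different core than the one carried by compound 3.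

Compound 4 `CC1=CC[C@H](C(C)C)c2cc(C)c(OC(=O)c3ccc(C)cc3)cc21` differs from compound 3 by methyl in place of nitro on an aromatic carbon. Among the measured compounds shown here, no measured step covers a nitro-to-methyl exchange, and the one step that does exist concerns other groups; it shows only that changes at this place can shift the number by a large amount in either direction. The expectation for compound 4 therefore rests on compound 3 as its closest neighbour and carries a wide range. The step from compound 3 to compound 4 in this assay is estimated as a number 12.9 percentage points lower from compound 3 to compound 4 (beyond the scatter). For compound 4 the estimate in this assay is 60%, with a range from 25% to 90%.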

Compound 4, a percentage reported as inhibition, at one concentration (the size of the read-out at that concentration, not a potency): 65%
Beside the measured number, compound 4's estimate is 5 percentage points below it; measured number inside the range.
By their numbers in this assay, from the lowest: compound 2; then compounds 4 and 3 (each within the scatter of the next); then compound 1.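

In this assay, exchanging nitro for methyl on an aromatic carbon, para to a large group, gives a number 7.9 percentage points lower from compound 3 to compound 4 (within the scatter), so this pair shows that the number at this place can hold across the change from 4-nitrophenyl to 4-methylphenyl on the shared core of compound 3 and compound 4. Among these compounds, until now the only step read at this place was large, a number 76.6 percentage points lower from compound 1 to compound 2 (beyond the scatter), and it was taken on the core of compound 1; the new pair shows that a large step is not the outcome of every exchange here, at least for these two groups on this core. Nothing available accounts for either the large step or the step within the scatter, and the pair alone offers no reason for the difference between them.

Open, from the compounds shown here alone, is whether the exchange of methoxy for trifluoromethyl would give a step of similar size on the core of compound 3, and whether nitro to methyl would hold on the core of compound 1. Also open, going by these compounds, is how an amine, a carboxylic acid or a longer alkyl chain at this place would read on either core.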